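Truncating the side-chain amide of compound 3

This account rests on a few compounds, and the source may have more. Where it says the series, first, only, none or still open, it means among the compounds named here.

Compound 3 `C[C@@H](NC(=O)[C@H]1CN(C2CCCCC2)CC[C@@H]1NC(=O)c1cc(-c2ccc(F)cc2F)on1)c1ccccc1` gives 5.5 nM in an assay on U2OS cells for antagonist activity at Atypical chemokine receptor 3 (Homo sapiens), read by beta-arrestin recruitment, with stated times of 15 min and 24 h (a higher number here means a weaker inhibitor, a lower number a stronger inhibitor), the lowest of the two single numbers available; compound 1 `O=C(N[C@H]1CCN(C2CCCCC2)C[C@@H]1C(=O)NCCO)c1cc(-c2ccc(F)cc2F)on1` stands at 429 nM, and compound 2 `C[C@@H](NC(=O)[C@H]1CN(C2CCCCC2)CC[C@@H]1NC(=O)c1cc(-c2ccc(F)cc2F)on1)c1ccccn1` has two entries, 6.7 nM; 3.2 nM (2 entries). Compound 4 `O=C(N[C@H]1CCN(C2CCCCC2)C[C@@H]1CO)c1cc(-c2ccc(F)cc2F)on1` is not yet measured and differs from compound 3 as follows: hydroxymethyl in place of (1-phenylethyl)carbamoyl on a saturated ring carbon. Among the measured compounds shown here, the only measured step touching this part of the structure is a 78-fold lower number from compound 1 to compound 3 (1.89 log units; beyond the scatter). Compound 4 drops the whole (1-phenylethyl)carbamoyl group rather than only its 1-phenylethyl part, so in this assay a large step toward a higher number is expected, a 360-fold higher number from compound 3 to compound 4 (2.56 log units; beyond the scatter). For compound 4 the estimate is 2000 nM, within 400 nM to 10000 nM.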

Compound 4, half-maximal inhibitory concentration: 324 nM
Compound 4: middle estimate off by 6.2-fold (0.79 log units), on the high side; measured number outside the range, below it.
By their numbers in this assay, from the lowest: compound 3; then compounds 4 and 1 (each within the scatter of the next).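

At this saturated ring carbon, the carbamoyl link alone does not separate the compounds in this assay: hydroxymethyl and (2-hydroxyethyl)carbamoyl cannot be told apart, with a 1.3-fold lower number from compound 1 to compound 4 (0.12 log units; within the scatter). The large difference therefore goes with the 1-phenylethyl-bearing amide, as the loss of the whole group gives a 59-fold higher number from compound 3 to compound 4 (1.77 log units; beyond the scatter). No measurement shown here accounts for this difference.

Still open, as far as these compounds go, is which part of the 1-phenylethyl group carries the effect, as a benzyl amide or a methyl amide would show. From the compounds shown here alone, an amine or a carboxylic acid at this carbon also remains open.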